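Adding to the Outer Phenyl of Compound 2

The compounds below may be only part of what the source reports. "The series", "measured", "known", "first", "only" and "open" are said of these compounds alone.

Within the data shown here, in a physicochemical assay for lipophilicity, using the shake flask method, in phosphate buffer, measured as octanol-water partition, with a stated time of 24 h, at pH 7.4, tested at 100 uM (on this read-out higher numbers stand for higher lipophilicity and lower numbers for lower lipophilicity), compound 2 (`O=C(O)CS(=O)(=O)c1ccc(OCc2cccc(-c3ccccc3)c2)cc1`) gives 2.13 as the lower of the two numbers so far. The larger compound 1 (`Cc1cc(OCCCS(C)(=O)=O)cc(C)c1-c1cccc(COc2ccc(CCC(=O)O)cc2)c1`) gives 3.75 and stands higher by a gap beyond the scatter. Compound 3 (`CCOc1ccc(-c2cccc(COc3ccc(S(=O)(=O)CC(=O)O)cc3)c2)c(Cl)c1`) changes compound 2 in one place: 2-chloro-4-ethoxyphenyl in place of phenyl on an aromatic carbon with 2-chloro-4-ethoxyphenyl in place of phenyl on an aromatic carbon, meta to a large group. Among the measured compounds shown here, no pair of measured compounds shows a change like this one, so the guide is thin: compound 3 is larger than compound 2, and the larger of the two measured compounds has the higher number. An upward step beyond the scatter is therefore expected, estimated as a number 0.97 log units higher from compound 2 to compound 3 (beyond the scatter) in this assay for now. Compound 3 is expected to read 3.1 with an estimated range from 2.6 to 3.6 on this scale.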

Compound 3, distribution coefficient: 3.12
For compound 3 the middle estimate is 0.02 log units below the measured one; the measured number falls inside the stated range.
By their numbers in this assay, from the lowest: compound 2; then compound 3; then compound 1.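

In this assay, the outer ring proves to be a place where a change moves the number: replacing phenyl with 2-chloro-4-ethoxyphenyl gives a number 0.99 log units higher from compound 2 to compound 3 (beyond the scatter) on the same core. The entering group has 10 heavy atoms against 6 and brings 1 hydrogen-bond acceptor against 0, yet the number still rises, so a new acceptor in this group does not prevent an upward step. Nothing shown gives a reason for this rise.

From the compounds shown here alone, the chlorine and the ethoxy group arrive together, so their separate shares of the step stay unknown, as does whether either alone would give a step beyond the scatter. Going by these compounds, it also remains open how the number would respond at this position to a ring carrying an amine or a nitrile.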